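This account rests on a few compounds, and the source may have more. Where it says the series, first, only, none or still open, it means among the compounds named here.

Compound 1 `COc1ccc(C2N=C(SCc3ccccc3Cl)NC(C)=C2C(=O)Nc2ccc(Br)cc2)cc1` is the reference of the pair; in a functional assay on the whole organism (artery, strain albino) with Rattus norvegicus as the target, with a stated time of 240 min, at a dose of 10 mg/kg by the oral route (a lower number here means less inhibition, a higher number more inhibition at the dose given (going by the name of the read-out)), compound 1 gives 15.4%. Compound 2 `COc1ccc(C2N=C(SCc3cccc(Cl)c3)NC(C)=C2C(=O)Nc2ccc(Br)cc2)cc1` differs from it by 3-chlorophenyl in place of 2-chlorophenyl on a saturated chain carbon bound to a sulfur; in this assay compound 2 gives 33.8%, a step of a number 18.4 percentage points higher from compound 1 to compound 2 (beyond the scatter). Compound 3 `CC1=C(C(=O)Nc2ccc([N+](=O)[O-])cc2)C(c2ccc(Br)cc2)N=C(SCc2ccccc2Cl)N1` carries a different core; the difference between the core of compound 3 and the core of compound 1 is not broken down here. In this assay compound 3 gives 15.4%, the same figure as compound 1 at the digits shown. Compound 4 `CC1=C(C(=O)Nc2ccc([N+](=O)[O-])cc2)C(c2ccc(Br)cc2)N=C(SCc2cccc(Cl)c2)N1`, not yet measured, differs from compound 3 by 3-chlorophenyl in place of 2-chlorophenyl on a saturated chain carbon bound to a sulfur, the same change as from compound 1 to compound 2. Within the data shown here, an upward step of a number 14.6 percentage points higher from compound 3 to compound 4 (beyond the scatter) is expected, resting on the single earlier step of a number 18.4 percentage points higher from compound 1 to compound 2 (beyond the scatter). Compound 4 is therefore estimated at 30%, between 14% and 46%.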

Compound 4, a percentage reported as inhibition, in the whole organism at one dose (the size of the read-out at that dose, not a potency): 11.8%
Compound 4: the middle estimate sits 18.2 percentage points above what was measured; measured number outside the range, below it.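

In this assay the same swap of 2-chlorophenyl for 3-chlorophenyl gives a step of a number 3.6 percentage points lower from compound 3 to compound 4 (within the scatter), so the rise seen on the core of compound 1 does not reappear on the core of compound 3: the same change on two cores in this assay, a number 18.4 percentage points higher (beyond the scatter) from compound 1 to compound 2 and a number 3.6 percentage points lower (within the scatter) from compound 3 to compound 4, 22 percentage points apart, beyond the scatter of two such steps. For these two pairs, the outcome of this change therefore depends on the core, and the step on one core does not predict the step on the other. The data do not show which part of the core difference matters, and two pairs give no rule for other cores.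

From the compounds shown here alone, only the two chlorophenyl groups appear at this place, so it remains open how a plain phenyl, a pyridine or an amine on that saturated chain carbon bound to a sulfur would behave on either core.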